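Two ester attachments, one amino-acid swap, one estimate

The compounds below may be only part of what the source reports. "The series", "measured", "known", "first", "only" and "open" are said of these compounds alone.

Four compounds are built from the same set of atoms arranged in two different core patterns. Compound 1 `N[C@@H](CC(=O)OC[C@H]1O[C@@H](n2cc(F)c(=O)[nH]c2=O)C[C@@H]1O)C(=O)O` carries a 2-amino-2-carboxyethyl group on a carbonyl carbon, and compound 2 `CC(C)[C@H](N)C(=O)OC[C@H]1O[C@@H](n2cc(F)c(=O)[nH]c2=O)C[C@@H]1O` carries 1-amino-2-methylpropyl at that position. In a functional assay on ZR-75-1 cells (Homo sapiens) for inhibition, read by MTT assay, with a stated time of 24 h (a higher number here means a weaker inhibitor of growth, a lower number a stronger inhibitor of growth), compound 1 gives 3900000 nM, while compound 2 gives 2500000 nM. The change between them is 1-amino-2-methylpropyl in place of 2-amino-2-carboxyethyl on a carbonyl carbon, and the step it produced was a 1.6-fold lower number from compound 1 to compound 2 (0.19 log units; within the scatter).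

Compound 3 `N[C@@H](CC(=O)O[C@H]1C[C@H](n2cc(F)c(=O)[nH]c2=O)O[C@@H]1CO)C(=O)O` has the same atoms as compound 1 joined in a different way; the difference between the two cores is not broken down here. In this assay compound 3 gives 3100000 nM, a value that sits among those of compound 1 and compound 2 with no separation beyond the scatter.

Compound 4 `CC(C)[C@H](N)C(=O)O[C@H]1C[C@H](n2cc(F)c(=O)[nH]c2=O)O[C@@H]1CO` has not been measured. It differs from compound 3 by 1-amino-2-methylpropyl in place of 2-amino-2-carboxyethyl on a carbonyl carbon, the same change that turns compound 1 into compound 2, at a place described in identical terms. Because the measured pair moved only by a 1.6-fold lower number from compound 1 to compound 2 (0.19 log units; within the scatter), the expected step here is a 1.6-fold lower number from compound 3 to compound 4 (0.19 log units; within the scatter). On that basis compound 4 is estimated at 2000000 nM in this assay, with the likely range expected to run from 900000 nM to 4500000 nM.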

Compound 4, concentration for 50% growth inhibition: 2100000 nM
The estimate for compound 4 lay 1.1-fold (0.02 log units) below the measured number; measured number inside the range.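

In this assay, putting 1-amino-2-methylpropyl in place of 2-amino-2-carboxyethyl on the carbonyl carbon of the core of compound 3 gave a 1.5-fold lower number from compound 3 to compound 4 (0.17 log units; within the scatter). Set beside the same change on the core of compound 1, the two steps show no difference, so in this series the change carried from one core to the other without any detectable shift in its size: the same change on two cores in this assay, a 1.6-fold lower number (0.19 log units; within the scatter) from compound 1 to compound 2 and a 1.5-fold lower number (0.17 log units; within the scatter) from compound 3 to compound 4, 1.1-fold (0.02 log units) apart, within the scatter of two such steps. Among the compounds shown here, this agreement is a weak test, however, since each step on its own lies within the scatter; the four compounds show that the change behaves alike on both cores only in the sense that neither step can be told from no step at all, and they do not show that a change with a step beyond the scatter would carry over in the same way.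

The compounds shown leave open whether another group on that carbonyl carbon, such as a longer carbon chain, a simple amine without the carboxylic acid or a phenyl ring, would give a step beyond the scatter. They also leave open whether the two cores would still respond alike to such a group.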